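Swapping a tert-butylphenyl for a nitrophenyl: expected cytotoxicity

The source may hold more compounds than are shown below. What is called first, only, known or untested is meant among the compounds shown, and "the series" means these compounds.

This series shares one core, seen in compound 1 `COC(=O)c1ccc(NCc2cncn2Cc2ccc(C#N)cc2)cc1-c1ccccc1`, and varies only the group carried on a saturated chain carbon bound to an aromatic nitrogen. The read-out is a toxicity assay on NIH3T3 cells (Mus musculus) for cytotoxicity, read by resazurin assay; on this read-out higher numbers stand for an effect only at larger amounts of compound and lower numbers for an effect already at smaller amounts. In this assay compound 1 gives only a limit, > 10000 nM. Compound 2 `COC(=O)c1ccc(NCc2cncn2Cc2ccc(C)cc2)cc1-c1ccccc1` gives 50000 nM in this assay. Among the compounds with values here, the one step between measured compounds, a step that the limit leaves unreadable from compound 1 to compound 2, cannot be sized because the limit of > 10000 nM in this assay, at which 1 of the 3 values shown sits, holds one end of it. Compound 3 `COC(=O)c1ccc(NCc2cncn2Cc2ccc(C(C)(C)C)cc2)cc1-c1ccccc1` has no value in this assay; its entry reads "not determined" (no result reported), so it stands nowhere on the numbers shown.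

Compound 4 `COC(=O)c1ccc(NCc2cncn2Cc2cccc([N+](=O)[O-])c2)cc1-c1ccccc1` differs from compound 3 by one change: 3-nitrophenyl in place of 4-(tert-butyl)phenyl on a saturated chain carbon bound to an aromatic nitrogen. Within the data shown here, no measured step bears on this change, and the only step in hand is unreadable, so neither a size nor a direction can be taken from the data. What is known is that both measured values sit in the same high region of concentration, and compound 4 is expected to sit in that region too. Compound 4 is therefore estimated at 40000 nM in this assay, with a range from 10000 nM to 150000 nM.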

Compound 4, half-maximal effective concentration: > 10000 nM
Compound 4: only a limit was reported; the forecaster's own chance of this, stated with the estimate: 40%; the middle value is on the limit's open side.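

Compound 4 gives only a limit in this assay, so its steps from compound 1 and from compound 2 cannot be read: the limit of > 10000 nM in this assay, at which 2 of the 4 values shown sit.

The compounds shown leave open whether the 3-nitrophenyl of compound 4 changes cytotoxicity at all compared with the 4-methylphenyl of compound 2, and where compound 3 stands.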